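This account rests on a few compounds, and the source may have more. Where it says the series, first, only, none or still open, it means among the compounds named here.

Compound 1 `CC(C)CC1OCCC(Cl)=C1[Si](C)(C)C` gives 66000 nM in a functional assay on A2780 cells (Homo sapiens) for antiproliferative activity; a lower number here means a stronger inhibitor of growth, a higher number a weaker inhibitor of growth. Compound 2 `C[C@H]1CC(Cl)=C([Si](C)(C)C)[C@@H](C2CCCCC2)O1` gives 32000 nM in this assay. Compound 3 `CC[C@H]1CC(Cl)=C([Si](C)(C)C)[C@@H](C2CCCCC2)O1` gives 35000 nM in this assay.

Among these three, compound 2 has the lowest number. Compound 3 sits next to it, the step of a 1.1-fold higher number from compound 2 to compound 3 (0.04 log units; within the scatter) lying within the scatter, so no order between the two can be claimed. Compound 1 stands furthest away, its number being clearly higher than that of compound 2.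

Compound 4 `C[Si](C)(C)C1=C(Cl)C[C@H](Cc2ccccc2)O[C@@H]1C1CCCCC1` differs from compound 2 by phenyl in place of hydrogen on a saturated chain carbon bound to a saturated ring carbon. Going by the values given here, the one measured step that touches the same place is a 1.1-fold higher number from compound 2 to compound 3 (0.04 log units; within the scatter), which did not move the number beyond the scatter. Among the compounds with values here, whether a phenyl at that place behaves like the methyl cannot be read from the measured compounds; the measured step is the only guide. On that basis the number for compound 4 in this assay is expected to stay close to that of compound 2, with a step of a 1.1-fold lower number from compound 2 to compound 4 (0.03 log units; within the scatter) that is expected to be small. Compound 4 is estimated at 30000 nM, with a likely range from 12000 nM to 80000 nM.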

Compound 4, concentration for total growth inhibition: 78000 nM
For compound 4 the middle estimate is 2.6-fold (0.41 log units) below the measured one; low and high end bracket the measured number.
By their numbers in this assay, from the lowest: compounds 2, 3, 1 and 4 (each within the scatter of the next, the first and the last beyond it).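

At the saturated chain carbon bound to a saturated ring carbon, the earlier methyl left the number within the scatter, but phenyl does not: this assay shows a 2.4-fold higher number from compound 2 to compound 4 (0.39 log units; beyond the scatter) and also a 2.2-fold higher number from compound 3 to compound 4 (0.35 log units; beyond the scatter) as a modest change. This place therefore responds to what it carries, and here the change runs towards weaker inhibition of growth, so the methyl step could not stand as a guide for every group at this place. No available evidence explains this result.

Going by these compounds, it remains open whether the shift follows from the aromatic ring itself or from the six added carbon atoms, which a cyclohexyl group at this place could help to separate. On these data alone, what an amine, a carboxylic acid or a longer chain would do here also remains open.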